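Thiophene for Oxazole: Expected Oral Exposure of Compound 3

This account rests on a few compounds, and the source may have more. Where it says the series, first, only, none or still open, it means among the compounds named here.

Of the compounds shown here, two of a shared core have been measured in an ADME assay on the whole organism (Rattus norvegicus) for pharmacokinetics, at a dose of 1 mg/kg by the oral route; a higher number here means that a larger share of the oral dose reaches the circulation, a lower number that a smaller share of the oral dose reaches the circulation. Compound 1 `COc1ccc(C(=O)C2=C(O)C(=O)N(c3ccc(-c4ccon4)cc3)C2c2ccccc2OCCO)cc1` gives 9%. Among the measured compounds shown here, compound 2 `CC(C)(C)C(=O)C1=C(O)C(=O)N(c2ccc(-c3ccon3)cc2)C1c1ccccc1OCCO` gives 49.9%, the higher of the two numbers, with compound 1 as its only neighbour on this scale. For the measured compounds named here, the single measured step, a number 40.9 percentage points higher from compound 1 to compound 2 (beyond the scatter), concerns the group on the carbonyl carbon and not the ring that is altered next. Compound 3 `CC(C)(C)C(=O)C1=C(O)C(=O)N(c2ccc(-c3ccsc3)cc2)C1c1ccccc1OCCO` differs from compound 2 by thiophen-3-yl in place of 1,2-oxazol-3-yl on an aromatic carbon. Going by the values given here, no measured step touches this position, so nothing in the data speaks for a shift in either direction, and the expectation is a step that stays within the scatter. The estimate for compound 3 in this assay is therefore 45%, between 20% and 70%, which means an expected step of a number 4.9 percentage points lower from compound 2 to compound 3 (within the scatter).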

Compound 3, oral bioavailability: 39.5%
Compound 3: middle estimate off by 5.5 percentage points, on the high side; the measured number falls inside the stated range.
By their numbers in this assay, from the lowest: compound 1; then compound 3; then compound 2.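

Among the compounds shown here, the position on the six-membered aromatic ring, which no earlier pair of compounds had touched, proves not to be silent in this assay: thiophen-3-yl in place of 1,2-oxazol-3-yl gives a number 10.4 percentage points lower from compound 2 to compound 3 (beyond the scatter) as a modest but real change. This step is smaller than the one seen at the carbonyl carbon, a number 40.9 percentage points higher from compound 1 to compound 2 (beyond the scatter), so the 1,2-oxazol-3-yl group can be exchanged here with part of the oral bioavailability retained. Nothing measured alongside this result explains the step.

As far as these compounds go, whether an amine, a carboxylic acid or a plain phenyl ring at this position would raise or lower oral bioavailability remains open. Also open, from the compounds shown here alone, is whether the same exchange would give a similar step with 4-methoxyphenyl rather than tert-butyl on the carbonyl carbon.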